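Moving the ring nitrogen in a hydrazone series

The source may hold more compounds than are shown below. What is called first, only, known or untested is meant among the compounds shown, and "the series" means these compounds.

Three compounds sharing one core differ only in the aromatic group on a carbon with a double bond to nitrogen. Compound 1 `C/C(=N\Nc1ncc(Cl)c(Nc2cccc(NC(=O)/C=C/CN(C)C)c2)n1)c1ccc(F)cc1F` gives 3460 nM in an ADME assay on HT-29 cells (Homo sapiens) for inhibition, read by MTT assay, with a stated time of 72 h; a lower number here means a stronger inhibitor, a higher number a weaker inhibitor. Compound 2 `COc1ccc(/C(C)=N/Nc2ncc(Cl)c(Nc3cccc(NC(=O)/C=C/CN(C)C)c3)n2)cc1` gives 6830 nM in this assay, and compound 3 `C/C(=N\Nc1ncc(Cl)c(Nc2cccc(NC(=O)/C=C/CN(C)C)c2)n1)c1cccnc1` gives 9660 nM, the highest of the three numbers. The steps were a 2.0-fold higher number from compound 1 to compound 2 (0.30 log units; within the scatter), a 2.8-fold higher number from compound 1 to compound 3 (0.45 log units; beyond the scatter) and a 1.4-fold higher number from compound 2 to compound 3 (0.15 log units; within the scatter), so exchanging one aromatic group for another at this place has moved the number only modestly.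

Compound 4 `C/C(=N\Nc1ncc(Cl)c(Nc2cccc(NC(=O)/C=C/CN(C)C)c2)n1)c1ccncc1` differs from compound 3 by pyridin-4-yl in place of pyridin-3-yl on a carbon with a double bond to nitrogen. Among the compounds with values here, no measured step shifts a ring nitrogen within the same ring, so the closest guide is the small size of every step seen so far. The expectation is therefore a step of a 1.1-fold lower number from compound 3 to compound 4 (0.03 log units; within the scatter), not beyond the scatter, in this assay. Compound 4 is estimated at 9000 nM, with a likely range from 4000 nM to 20000 nM.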

Compound 4, half-maximal inhibitory concentration: 10900 nM
Estimate against measurement, compound 4: 1.2-fold (0.08 log units) below; measured number inside the range.
By their numbers in this assay, from the lowest: compounds 1, 2, 3 and 4 (each within the scatter of the next, the first and the last beyond it).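

Moving the ring nitrogen, from pyridin-3-yl to pyridin-4-yl, gives a 1.1-fold higher number from compound 3 to compound 4 (0.05 log units; within the scatter) in this assay, so at this place the data do not separate these two pyridine groups. Compound 4 also sits much as compound 3 does against the other aromatic groups: replacing 4-methoxyphenyl gives a 1.6-fold higher number from compound 2 to compound 4 (0.20 log units; within the scatter), and replacing 2,4-difluorophenyl gives a 3.2-fold higher number from compound 1 to compound 4 (0.50 log units; beyond the scatter), so among these compounds only the 2,4-difluorophenyl compound stands apart from the pyridines. Nothing available explains why the position of the nitrogen matters so little here.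

Still open, as far as these compounds go, is whether pyridin-2-yl, the remaining placement of the ring nitrogen, would fit the same picture. It is also unknown whether an aromatic ring carrying an amine or a carboxylic acid would move the number further than any group shown.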